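The compounds below may be only part of what the source reports. "The series", "measured", "known", "first", "only" and "open" are said of these compounds alone.

Two compounds of the series carry numbers in a functional assay on CHO cells for agonist activity at Glucose-dependent insulinotropic receptor (Homo sapiens), read by HTRF and cAMP accumulation; a higher number here means that more compound is needed for the effect, a lower number that less compound is needed. Compound 1 `CCOC(=O)[C@](C)(Cc1ccccc1)c1c(C)cnc2c(-c3ccc(C(F)(F)F)cc3)cnn12` gives 1 nM, and compound 2 `CCOC(=O)[C@](C)(Cc1ccccc1)c1ccnc2c(-c3ccc(C(F)(F)F)cc3)c(C)nn12` gives 23 nM. Among the measured compounds shown here, compound 1 therefore stands at the lowest of the two numbers, and its gap to compound 2 lies beyond the scatter; as no single-point step links these two compounds, only their two values are noted. Compound 3 `CCOC(=O)[C@](C)(Cc1ccccc1)c1c(Cl)cnc2c(-c3ccc(C(F)(F)F)cc3)cnn12` is not yet measured in this assay. It differs from compound 1 by chloro in place of methyl on an aromatic carbon. For the measured compounds named here, no measured pair shows this change, so its size cannot be read from the data. The step is expected to be small, within the scatter or slightly upward, estimated at a 1.5-fold higher number from compound 1 to compound 3 (0.18 log units; within the scatter). Compound 3 is accordingly expected to come in near 1.5 nM, with a range of 0.4 nM to 6 nM.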

Compound 3, half-maximal effective concentration: 3 nM
Compound 3: the middle estimate sits 2.0-fold (0.30 log units) below what was measured; the measured number falls inside the stated range.
By their numbers in this assay, from the lowest: compound 1; then compound 3; then compound 2.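

In this assay, chloro in place of methyl on this aromatic carbon, ortho to a large group, gives a 3.0-fold higher number from compound 1 to compound 3 (0.48 log units; beyond the scatter). Among the compounds shown here, this is the first single-place step, and it shows that the position responds to the exchange of these two groups, though only modestly, with methyl holding the lower number of the pair. The data at hand offer no measurement that bears on why the two groups differ.

On these data alone, only methyl and chloro have been compared at this position, so the effect of a bare hydrogen, fluoro, methoxy, nitrile or an amine there remains open. Also open, as far as these compounds go, is whether the same step would hold if the ethyl ester were replaced by a carboxylic acid or an amide.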